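The source may report more compounds than this note shows. Statements on the series, on what has been measured and on what is new or still open speak of the compounds shown alone.

Measured so far:
- compound 1 `C=CC(=O)Nc1cc2c(N3CCc4ccccc43)ncnc2cc1O[C@@H]1CCOC1`: 2710 nM
- compound 2 `C=C(C)C(=O)Nc1cc2c(N3CCc4ccccc43)ncnc2cc1O[C@@H]1CCOC1`: 4910 nM
- compound 3 `CN(C)C/C=C/C(=O)Nc1cc2c(N3CCc4ccccc43)ncnc2cc1O[C@@H]1CCOC1`: 1230 nM

All three values come from a functional assay on PC-3 cells (Homo sapiens) for antiproliferative activity, read by MTT assay, with a stated time of 72 h; a higher number here means a weaker inhibitor, a lower number a stronger inhibitor. Among them compound 3 stands lowest; the step of a 2.2-fold lower number from compound 1 to compound 3 (0.34 log units; beyond the scatter) and the step of a 4.0-fold lower number from compound 2 to compound 3 (0.60 log units; beyond the scatter) are both beyond the scatter, while a 1.8-fold higher number from compound 1 to compound 2 (0.26 log units; within the scatter) is not.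

Compound 4 `O=C(/C=C/CN1CCC(CO)CC1)Nc1cc2c(N3CCc4ccccc43)ncnc2cc1O[C@@H]1CCOC1` differs from compound 3 by 4-(hydroxymethyl)piperidin-1-yl in place of dimethylamino on a saturated chain carbon bound to a double-bonded chain carbon. Among the measured compounds shown here, the measured steps only bear on this change indirectly: a 2.2-fold lower number from compound 1 to compound 3 (0.34 log units; beyond the scatter) and a 4.0-fold lower number from compound 2 to compound 3 (0.60 log units; beyond the scatter) show that the 3-(dimethylamino)prop-1-en-1-yl chain gave a modest gain over vinyl and 1-methylethenyl, but no measured step varies the amine itself. A step of no more than the scatter is therefore expected in this assay, with compound 4 estimated at 1200 nM (range 500 nM to 3000 nM), which means an expected step of a 1.0-fold lower number from compound 3 to compound 4 (0.01 log units; within the scatter).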

Compound 4, half-maximal inhibitory concentration: 3310 nM
Compound 4: the middle estimate sits 2.8-fold (0.44 log units) below what was measured, and the stated range ends below it.
By their numbers in this assay, from the lowest: compound 3; then compounds 1, 4 and 2 (each within the scatter of the next).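

In this assay, the amine on the saturated chain carbon bound to a double-bonded chain carbon matters: 4-(hydroxymethyl)piperidin-1-yl in place of dimethylamino gives a 2.7-fold higher number from compound 3 to compound 4 (0.43 log units; beyond the scatter). The gain of the dimethylamino chain does not carry over to this amine, which gives a 1.2-fold higher number from compound 1 to compound 4 (0.09 log units; within the scatter) and a 1.5-fold lower number from compound 2 to compound 4 (0.17 log units; within the scatter), both within the scatter. No measurement here accounts for the loss. Still open, going by these compounds, is whether the ring or its hydroxymethyl drives the step; unsubstituted piperidin-1-yl would separate the two, and morpholin-4-yl would test a ring oxygen.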